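Nitro in place of chloro on the acetamido series

This account rests on a few compounds, and the source may have more. Where it says the series, first, only, none or still open, it means among the compounds named here.

Compound 1 (`CC(=O)Nc1ccc(-c2nc3ccccc3s2)cc1Cl`) stands in a functional assay on MCF7 cells (Homo sapiens) for antiproliferative activity (a higher number here means a weaker inhibitor, a lower number a stronger inhibitor), only at the limit of > 10 nM and has no exact number. Compound 2 (`CC(=O)N(C(C)=O)c1ccc(-c2nc3ccccc3s2)cc1Cl`) likewise stands only at the limit of > 10000 nM in this assay. Going by the values given here, the one measured step, a step that the two limits leave unreadable from compound 1 to compound 2 (acetyl in place of hydrogen on an amide-type nitrogen), is unreadable and gives no size for compound 3 (`CC(=O)Nc1ccc(-c2nc3ccccc3s2)cc1[N+](=O)[O-]`). That change is nitro in place of chloro on an aromatic carbon. The estimated step is a step that the limit leaves unreadable from compound 1 to compound 3 in this assay and is loosely expected toward weaker inhibition. Compound 3 is expected at 1000 nM in this assay with an estimated range from 30 nM to 10000 nM overall.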

Compound 3, half-maximal inhibitory concentration: > 1000 nM
Compound 3: only a limit was reported; the forecaster's own chance of this, stated with the estimate: 40%; the middle value lies on the limit itself.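

Compound 1 and compound 3 are both reported only as limits in this assay, so the step between them cannot be read. The compounds shown leave open whether nitro or chloro gives the stronger inhibitor.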